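Adding a Second Fluorine to a Two-Ring Alkene Activator

This account rests on a few compounds, and the source may have more. Where it says the series, first, only, none or still open, it means among the compounds named here.

Compound 1, `Fc1cccc(/C=C/c2ccccc2)c1`, gives 3100 nM in an assay on HepG2 cells for activation of nuclear factor erythroid 2-related factor 2 (Homo sapiens), read by a luciferase reporter, with a stated time of 5 h; on this read-out lower numbers stand for an effect already at smaller amounts and higher numbers for an effect only at larger amounts of compound. Compound 2, `Fc1cccc(/C=C/c2ccccc2F)c1`, reaches only the limit > 15000 nM in this assay. Compound 3, `Fc1cccc(/C=C/c2cccc(F)c2)c1`, gives 1000 nM in this assay.

Compound 3 holds the lower of the two plain numbers shown; the gap to the other one is a 3.1-fold lower number from compound 1 to compound 3 (0.49 log units; beyond the scatter). Compound 4, `Fc1cccc(/C=C/c2cc(F)ccc2F)c1`, differs from compound 3 by fluoro in place of hydrogen on an aromatic carbon. The closest measured step is an at least 4.8-fold higher number from compound 1 to compound 2 (0.68 log units; beyond the scatter), which is only a bound because of the limit of > 15000 nM in this assay, at which 1 of the 3 values shown sits. The same change is therefore expected to raise the number in this assay by a step beyond the scatter. Compound 4 is estimated at 8000 nM, between 2500 nM and 25000 nM. The expected step is an 8.0-fold higher number from compound 3 to compound 4 (0.90 log units; beyond the scatter).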

Compound 4, half-maximal effective concentration: 300 nM
Compound 4: the middle estimate sits 27-fold (1.43 log units) above what was measured; the whole stated range lies above it.
By their numbers in this assay, from the lowest: compound 4; then compound 3; then compound 1. At a limit, above all of these: compound 2.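

Set ortho to a group of 9 heavy atoms, the added fluoro now gives a 3.3-fold lower number from compound 3 to compound 4 (0.52 log units; beyond the scatter) in this assay, so this change does not push the number the same way on every core: the same change on two cores in this assay, an at least 4.8-fold higher number (0.68 log units; beyond the scatter) from compound 1 to compound 2 and a 3.3-fold lower number (0.52 log units; beyond the scatter) from compound 3 to compound 4, at least 16-fold (1.20 log units) apart, beyond the scatter of two such steps

The value of compound 2 is a limit, so the next step is only a bound. Fluoro para to the first added fluoro gives an at least 50-fold lower number from compound 2 to compound 4 (1.69 log units; beyond the scatter), a larger step than on the core of compound 1: the same change on two cores in this assay, a 3.1-fold lower number (0.49 log units; beyond the scatter) from compound 1 to compound 3 and an at least 50-fold lower number (1.69 log units; beyond the scatter) from compound 2 to compound 4, at least 16-fold (1.20 log units) apart, beyond the scatter of two such steps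

On these data alone, whether this reversal belongs to fluoro alone remains open. A methoxy group or an amine at the same place would test that.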